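Swapping methoxy for cyano on a thione core

A few compounds are considered here, and "the series" means these few. Any claim that something is new, unique, unknown or untested is made for them only; others in the source may bear on it.

For the measured compounds named here, compound 2 `COc1ccc(-c2csc(=S)[nH]2)cc1` stands highest of the two numbers so far: in an assay on isolated protein for inhibition of Indoleamine 2,3-dioxygenase 1 (Homo sapiens), read by colorimetric assay, with stated times of 10 min and 30 min, tested at 100 uM (a higher number here means more inhibition at the concentration tested (going by the name of the read-out), a lower number less inhibition), compound 2 gives 68%, while compound 1 `COc1ccccc1-c1c[nH]c(=S)s1` gives 12%, a gap beyond the usual scatter. Compound 3 `N#Cc1ccc(-c2csc(=S)[nH]2)cc1` is not yet measured; it differs from compound 2 by cyano in place of methoxy on an aromatic carbon. Going by the values given here, no measured step of this kind exists to lean on. In this assay the expected step is a number 18 percentage points lower from compound 2 to compound 3 (beyond the scatter), a modest loss lying near the edge of the scatter. Compound 3 is therefore estimated at 50%, within a range from 20% to 80%.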

Compound 3, a percentage reported as inhibition, at one concentration (the size of the read-out at that concentration, not a potency): 8%
The estimate for compound 3 lay 42 percentage points above the measured number; measured number below the stated range.
By their numbers in this assay, from the lowest: compounds 3 and 1 (each within the scatter of the next); then compound 2.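

Cyano in place of methoxy on an aromatic carbon gives a number 60 percentage points lower from compound 2 to compound 3 (beyond the scatter), so the group at this position, para to a group of 6 heavy atoms, matters greatly in this assay. The two groups have the same counts of heavy atoms and hydrogen-bond acceptors, and neither has a ring or a net charge, so these counts do not separate them. Nothing available explains the drop. From the compounds shown here alone, how an amine, a carboxylic acid or a longer chain such as butoxy would behave at this position remains open.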